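4-Chlorophenyl for furan-3-yl next to the ring sulfur

The source may hold more compounds than are shown below. What is called first, only, known or untested is meant among the compounds shown, and "the series" means these compounds.

The series shares the core of compound 1 `Cc1csc(N)c1C(=O)c1ccc(Cl)cc1`. In an assay on CHO cells for displacement of a labelled ligand from adenosine receptor A3 (Homo sapiens), read by scintillation counting, tested at 10 uM (on this read-out higher numbers stand for more inhibition at the one concentration tested (going by the name of the read-out) and lower numbers for less inhibition), compound 1 gives 1%. Compound 2 `COc1ccc(-c2sc(N)c(C(=O)c3ccc(Cl)cc3)c2C)cc1` carries 4-methoxyphenyl in place of hydrogen on an aromatic carbon, and in this assay compound 2 gives 1%; the step of no change at the digits printed from compound 1 to compound 2 (within the scatter). Compound 3 `CC(C)(C)Cc1c(-c2ccoc2)sc(N)c1C(=O)c1ccc(Cl)cc1`, which carries a neopentyl group and a furan-3-yl on the core, gives in this assay 1%, level with compounds 1 and 2 at the digits shown, so the whole set sits at one level.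

Compound 4 `CC(C)(C)Cc1c(-c2ccc(Cl)cc2)sc(N)c1C(=O)c1ccc(Cl)cc1` differs from compound 3 in one place: 4-chlorophenyl in place of furan-3-yl on an aromatic carbon, on the aromatic carbon of the five-membered aromatic ring with 1 sulfur, next to the ring sulfur. Going by the values given here, no measured step exchanges one aryl for another at this position. Among the compounds with values here, the only step in hand, from compound 1 to compound 2, put an aryl group onto the core without moving the read-out, and compound 3 with its furan-3-yl sits at the same level. A step of no size beyond the scatter is therefore expected in this assay, no change at the digits printed from compound 3 to compound 4 (within the scatter). Compound 4 is expected to give 1%, within -8% to 10%.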

Compound 4, a percentage reported as inhibition, at one concentration (the size of the read-out at that concentration, not a potency): 1%
Compound 4: the middle estimate sits on the measured number at the digits printed, within the range that was stated.
By their numbers in this assay, from the lowest: compounds 1, 2, 3 and 4 (each within the scatter of the next).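

In this assay, putting 4-chlorophenyl in place of furan-3-yl on the aromatic carbon next to the ring sulfur gives a step that reads no change at the digits printed from compound 3 to compound 4 (within the scatter). Going by these compounds alone, this is the first direct exchange of one aryl for another at this position: a five-membered aromatic ring with 1 hetero atom gives way to a six-membered aromatic ring of carbon only bearing chlorine, with the neopentyl group unchanged, and the read-out does not separate the two. No measurement at hand offers an explanation for this flat result.

With all the compounds shown at one level, nothing yet indicates which change on the shared core, if any, would raise the read-out. On these data alone, whether a carboxylic acid or an amine on the aryl group at this position, or a longer chain in place of neopentyl, would move it remains open.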